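This account rests on a few compounds, and the source may have more. Where it says the series, first, only, none or still open, it means among the compounds named here.

Measured so far:

Compound 1 `CCN1CCN(CC(O)Cn2c([N+](=O)[O-])cnc2C)CC1` gives 4940000 nM in a toxicity assay on HeLa cells (Homo sapiens) for cytotoxicity, read by MTT assay, with a stated time of 24 h; a lower number here means a stronger inhibitor, a higher number a weaker inhibitor.
Compound 2 `Cc1ncc([N+](=O)[O-])n1CC(O)CN1CCN(c2ccccn2)CC1` gives 1830000 nM in this assay.
Compound 3 `CCN1CCN(CC(O)Cn2cc([N+](=O)[O-])nc2C)CC1` in this assay reaches only a limit, > 5000000 nM.

Compound 1 and compound 2 share a core and differ in one place: pyridin-2-yl in place of ethyl on an amine nitrogen in a ring. That change produced a step of a 2.7-fold lower number from compound 1 to compound 2 (0.43 log units; beyond the scatter). Compound 3 has the same atoms as compound 1 joined differently; how the two cores differ is not broken down here. The value of compound 3 in this assay is a limit of the assay and not a number, and the limit of > 5000000 nM in this assay, at which 1 of the 3 values shown sits, tells where it sits.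

Compound 4 `Cc1nc([N+](=O)[O-])cn1CC(O)CN1CCN(c2ccccn2)CC1` has not yet been measured in this assay. It stands to compound 3 as compound 2 stands to compound 1, with the same change at the same place: pyridin-2-yl in place of ethyl on an amine nitrogen in a ring. Since compound 3 starts at a limit, the expectation for compound 4 rests on the measured step from compound 1 to compound 2, a 2.7-fold lower number from compound 1 to compound 2 (0.43 log units; beyond the scatter), applied to a starting point that is itself only a bound. The step is therefore expected to be an at least 2.0-fold lower number from compound 3 to compound 4 (0.30 log units; that floor lies within the scatter), a step of similar size to the earlier one, though there is a real chance that compound 4 also reports only a limit. Compound 4 is estimated at 2500000 nM in this assay, with a range from 1000000 nM to 6000000 nM.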

Compound 4, half-maximal inhibitory concentration: > 5000000 nM
Compound 4: only a limit was reported; the forecaster's own chance of this, stated with the estimate: 40%; at least 2.0-fold (0.30 log units) between middle value and limit.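

Compound 3 and compound 4 each reach only a limit in this assay, so no step between them can be read: the limit of > 5000000 nM in this assay, at which 2 of the 4 values shown sit.

The compounds shown leave open where the values of compound 3 and compound 4 truly lie, and whether pyridin-2-yl in place of ethyl on an amine nitrogen in a ring changes the number on the core of compound 3 as it does on the core of compound 1.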